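Isobutyl in Place of Isopropyl on the Ring Nitrogen of Compound 1

The source may hold more compounds than are shown below. What is called first, only, known or untested is meant among the compounds shown, and "the series" means these compounds.

Compound 1, `CC(C)N1CCN(c2ccc3c(c2)oc(=O)n3C(=O)NCCCCc2ccccc2)CC1`, gives 211 nM
Compound 2, `O=C(NCCCCc1ccccc1)n1c(=O)oc2cnccc21`, gives 3 nM
Compound 3, `CCOCCNC(=O)n1c(=O)oc2cc(C3CCN(C)CC3)ccc21`, gives 1050 nM

Of the compounds shown here, three have been measured in an assay on HEK293 cells for inhibition of acid ceramidase (Homo sapiens), read by fluorescence, with stated times of 10 min and 3 h; a lower number here means a stronger inhibitor, a higher number a weaker inhibitor. Among them compound 1 stands second highest of the three numbers. Its nearest neighbour is compound 3, whose number is higher than that of compound 1 by a margin beyond the usual scatter. Furthest away is compound 2, whose number is far lower than that of compound 1, again well beyond the scatter. Among the compounds with values here, none of these three pairs differs in only one place, so no single measured step is available to guide an expectation.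

The next compound, compound 4, `CC(C)CN1CCN(c2ccc3c(c2)oc(=O)n3C(=O)NCCCCc2ccccc2)CC1`, is the closest relative of compound 1 in the set. It differs in one place: isobutyl in place of isopropyl on an amine nitrogen in a ring. Read one bond further out, 4-isopropylpiperazin-1-yl becomes 4-isobutylpiperazin-1-yl, a change that adds one carbon to a chain on an amine nitrogen in a ring while keeping the shared core of compound 1 untouched.

With nothing measured to suggest otherwise, the step from compound 1 to compound 4 in this assay is expected to be small, in no firm direction, and not beyond the scatter. Compound 4 is therefore estimated at 200 nM, within a range of 90 nM to 450 nM. The expected step of a 1.1-fold lower number from compound 1 to compound 4 (0.02 log units; within the scatter) is thus essentially flat.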

Compound 4, half-maximal inhibitory concentration: 127 nM
Compound 4: the middle estimate sits 1.6-fold (0.20 log units) above what was measured; measured number inside the range.
By their numbers in this assay, from the lowest: compound 2; then compounds 4 and 1 (each within the scatter of the next); then compound 3.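

Within the data shown here, the step of a 1.7-fold lower number from compound 1 to compound 4 (0.22 log units; within the scatter) in this assay is the first comparison in this set between compounds that differ in only one place. It shows that, on this amine nitrogen in a ring, isobutyl and isopropyl cannot be told apart in this read-out, so adding one carbon to the chain at this position, with the shared core untouched, produces no resolvable difference between compound 1 and compound 4. Nothing available here gives a reason for this result.

The compounds shown leave open whether a longer chain such as n-hexyl, a benzyl group, a hydroxyethyl chain or a bare ring nitrogen bearing only hydrogen would stay within the scatter of these two values or move beyond it. Going by these compounds, compound 2 and compound 3 each differ from compound 1 in more than one place, and their steps from it cannot be read, so it also remains open how much any other part of these molecules contributes to the number.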